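The source may hold more compounds than are shown below. What is called first, only, known or untested is meant among the compounds shown, and "the series" means these compounds.

Measured compounds in an ADME assay on WI-38 cells (Homo sapiens) for cytotoxicity, read by MTT assay, with a stated time of 72 h; on this read-out lower numbers stand for stronger inhibition and higher numbers for weaker inhibition:
compound 1 `CN(C)CCn1cnnc1-c1cc(Oc2ccc(NC(=O)N/N=C/c3ccc(F)cc3Cl)cc2F)ccn1`, 2090 nM
compound 2 `CN(C)CCn1cnnc1-c1cc(Oc2ccc(NC(=O)N/N=C/c3cccc(Cl)c3Cl)cc2F)ccn1`, 6130 nM
compound 3 `CN(C)CCn1cnnc1-c1cc(Oc2ccc(NC(=O)N/N=C/c3cc(C(C)(C)C)cc(C(C)(C)C)c3O)cc2F)ccn1`, 2350 nM

Compound 2 stands highest of the three numbers in this assay, beyond the scatter from both compound 3 and compound 1, and is therefore the weakest inhibitor of the set. Compound 4 `CN(C)CCn1cnnc1-c1cc(Oc2ccc(NC(=O)N/N=C/c3ccc(O)c(Br)c3)cc2F)ccn1` differs from it by 3-bromo-4-hydroxyphenyl in place of 2,3-dichlorophenyl on a carbon with a double bond to nitrogen. Among the compounds with values here, the only measured step that touches this position is a 2.9-fold higher number from compound 1 to compound 2 (0.47 log units; beyond the scatter), a modest shift in which the halogen pattern on the aryl ring was changed. Compound 3, carrying a hydroxyl on its aryl ring, sits close to compound 1 rather than to compound 2. Compound 4 is therefore expected to move back toward the lower numbers, with a 1.9-fold lower number from compound 2 to compound 4 (0.28 log units; within the scatter) as the estimated step, giving an expected value of 3200 nM (range 1300 nM to 8000 nM).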

Compound 4, half-maximal inhibitory concentration: 5560 nM
The estimate for compound 4 lay 1.7-fold (0.24 log units) below the measured number, and the stated range covers the measured number.
By their numbers in this assay, from the lowest: compounds 1 and 3 (each within the scatter of the next); then compounds 4 and 2 (each within the scatter of the next).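

In this assay the change on the carbon with a double bond to nitrogen gives a 1.1-fold lower number from compound 2 to compound 4 (0.04 log units; within the scatter) and so leaves 3-bromo-4-hydroxyphenyl and 2,3-dichlorophenyl indistinguishable, although only the former carries a hydrogen-bond donor. Against 2-chloro-4-fluorophenyl the same group gives a 2.7-fold higher number from compound 1 to compound 4 (0.42 log units; beyond the scatter) and so compound 4, despite its hydroxyl, stands with compound 2 rather than with compound 1. As far as these compounds go, whether an aryl ring bearing an amine or a carboxylic acid would stay in this range remains open. No evidence shown accounts for the gap between these aryl groups.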